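Trifluoromethyl to methyl in a two-compound series

The source may hold more compounds than are shown below. What is called first, only, known or untested is meant among the compounds shown, and "the series" means these compounds.

Of the compounds shown here, two have numbers so far, both in a functional assay on A549 cells (Homo sapiens) for inhibition, read by MTT assay, with a stated time of 72 h; a lower number here means a stronger inhibitor, a higher number a weaker inhibitor. Compound 1 `COc1cc2c(Oc3ccc(NC(=O)c4nn(-c5ccc(F)c(Cl)c5)cc(C)c4=O)cc3)ccnc2cc1OCCCCCCC(=O)NO` gives 380 nM, and compound 2 `COc1cc2c(Oc3ccc(NC(=O)c4nn(-c5cccc(C(F)(F)F)c5)cc(C)c4=O)cc3)ccnc2cc1OCCCCCCC(=O)NO` gives 780 nM, the higher of the two numbers. Next is compound 3 `COc1cc2c(Oc3ccc(NC(=O)c4nn(-c5cccc(C)c5)cc(C)c4=O)cc3)ccnc2cc1OCCCCCCC(=O)NO`, which differs from compound 2 only by methyl in place of trifluoromethyl on an aromatic carbon, meta to a large group, so that 3-(trifluoromethyl)phenyl becomes 3-methylphenyl.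

For the measured compounds named here, only one measured step bears on this change: a 2.1-fold higher number from compound 1 to compound 2 (0.31 log units; beyond the scatter), with 3-(trifluoromethyl)phenyl in place of 3-chloro-4-fluorophenyl on an aromatic nitrogen. That step is modest, only just beyond the scatter, and it involves the same aryl substituent. Going by the values given here, no measured compound carries methyl on this ring, so the direction is poorly defined. A small step or none beyond the scatter is expected in this assay, with a slight lean towards a lower number than compound 2. For compound 3 the estimated value is 620 nM, with an expected range from 260 nM to 1400 nM.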

Compound 3, half-maximal inhibitory concentration: 280 nM
Compound 3: middle estimate off by 2.2-fold (0.35 log units), on the high side; the range from low to high includes it.
By their numbers in this assay, from the lowest: compounds 3 and 1 (each within the scatter of the next); then compound 2.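

In this assay, for the compounds shown here, methyl in place of trifluoromethyl on this aromatic carbon gives a 2.8-fold lower number from compound 2 to compound 3 (0.44 log units; beyond the scatter) and, unlike the earlier step, isolates the trifluoromethyl group as the only change. The earlier pair also changed the other substituents on this ring, whereas a 1.4-fold lower number from compound 1 to compound 3 (0.13 log units; within the scatter) now leaves 3-methylphenyl and 3-chloro-4-fluorophenyl undistinguished, and compound 2 alone stands apart as the weakest of the three, with its steps to both others beyond the scatter. The compounds shown offer no measurement that would explain why the trifluoromethyl group carries this cost here.

Going by these compounds, it remains open whether other groups on this carbon, such as an amine, a methoxy group, an ethyl group or plain hydrogen, would fall with methyl or with trifluoromethyl, so three compounds give only the first outline of what this position tolerates. The comparison also rests on a single cell read-out, which leaves open whether the same gap between methyl and trifluoromethyl would appear in any other assay on this series.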